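A few compounds are considered here, and "the series" means these few. Any claim that something is new, unique, unknown or untested is made for them only; others in the source may bear on it.

Measured compounds:
Compound 1 `O=CNc1ccc(C2=NNC(=O)CC2)cc1`: 3.74 ug/mL
Compound 2 `CC(C)NCC(=O)Nc1ccc(C2=NNC(=O)CC2)cc1`: about 46.4 ug/mL

In a functional assay for inhibition, with Homo sapiens as the target (a higher number here means that more compound is needed for the effect, a lower number that less compound is needed), compound 2 stands at the highest of these two numbers, with compound 1 as its nearest neighbour at 3.74 ug/mL. Among the compounds with values here, the only measured step is a 12-fold higher number from compound 1 to compound 2 (1.09 log units; beyond the scatter), a large rise. Compound 3 `C[N+]1(CC(=O)Nc2ccc(C3=NNC(=O)CC3)cc2)CCCC1` differs from compound 2 by a group of 6 heavy atoms (5 carbon, 1 nitrogen; one five-membered non-aromatic ring with 1 hetero atom) in place of a group of 4 heavy atoms (3 carbon, 1 nitrogen; no ring), on a saturated chain carbon bound to a carbonyl carbon. Within the data shown here, no measured step exchanges one amine-bearing group for another, so that large step is only a loose guide here, and any further shift is expected to be modest in either direction. Compound 3 is therefore estimated at 60 ug/mL, between 20 ug/mL and 150 ug/mL, a step of a 1.3-fold higher number from compound 2 to compound 3 (0.11 log units; within the scatter).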

Compound 3, half-maximal effective concentration: > 46.4 ug/mL
Compound 3 ended at the assay's limit (the forecaster's own chance of this, stated with the estimate: 20%); the middle value does not contradict the limit.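

In this assay compound 3 gives > 46.4 ug/mL, which is a limit of the assay and not a number. Replacing isopropylamino with the five-membered ring of net charge +1, on a saturated chain carbon bound to a carbonyl carbon, brings a number no lower from compound 2 to compound 3 (the limit leaves the size open), and the size of that step cannot be read. The comparison with the smallest compound can be read and shows an at least 12-fold higher number from compound 1 to compound 3 (1.09 log units; beyond the scatter).

The compounds shown do not separate the effect of the ring from that of the net charge. A pyrrolidine or a dimethylamino group at this place remains an open case.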